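Compound 3: replacing the 3,5-dimethoxyphenyl group

A few compounds are considered here, and "the series" means these few. Any claim that something is new, unique, unknown or untested is made for them only; others in the source may bear on it.

In a toxicity assay on HeLa cells (Homo sapiens) for cytotoxicity, read by colorimetric assay, with a stated time of 72 h (on this read-out higher numbers stand for lower toxicity in this test and lower numbers for higher toxicity in this test), compound 1 `CN1CCC(CCCC2CCN(c3nc(=O)c4cc(C(F)(F)F)cc([N+](=O)[O-])c4s3)CC2)CC1` gives 20100 nM. Compound 2 `COc1cc(OC)cc(N2CCN(c3nc(=O)c4cc(C(F)(F)F)cc([N+](=O)[O-])c4s3)CC2)c1` gives > 101000 nM, which is a limit of the assay and not a number. Compound 2 therefore stands at the limit of > 101000 nM in this assay, at which 1 of the 2 values shown sits.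

Compound 3 `O=C(CN1CCN(c2nc(=O)c3cc(C(F)(F)F)cc([N+](=O)[O-])c3s2)CC1)NCc1ccccc1` has (benzylcarbamoyl)methyl in place of 3,5-dimethoxyphenyl on an amine nitrogen in a ring. Among the measured compounds shown here, no measured pair shows this exchange, so any expectation for it is loose. Compound 1 at 20100 nM shows that a compound of this series can give a number in this assay. A modest move towards lower numbers is therefore expected, and it may not exceed the scatter. The expected change is an at least 1.4-fold lower number from compound 2 to compound 3 (0.15 log units; that floor lies within the scatter). For compound 3, the estimated value is 70000 nM, with an expected range from 25000 nM to 100000 nM.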

Compound 3, half-maximal cytotoxic concentration: 57100 nM
For compound 3 the middle estimate is 1.2-fold (0.09 log units) above the measured one, and the stated range covers the measured number.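

At the amine nitrogen in a ring, the exchange of 3,5-dimethoxyphenyl for (benzylcarbamoyl)methyl gives in this assay the first step readable at this place, with an at least 1.7-fold lower number from compound 2 to compound 3 (0.24 log units; that floor lies within the scatter) as its size. Compound 2 has a limit of the assay and not a number, so only a floor can be read for the step: the limit of > 101000 nM in this assay, at which 1 of the 3 values shown sits. With that floor inside the scatter, these two compounds do not yet show a change beyond it, though the position does accept a group with a carbonyl and an amide hydrogen and still gives a number.

From the compounds shown here alone, whether the carbonyl, the amide hydrogen or the benzyl end goes with the lower number remains open. So does the outcome with a carboxylic acid or a tertiary amine in place of the benzyl end.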